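Dichloro substitution on the aryl ring of compound 3

The source may hold more compounds than are shown below. What is called first, only, known or untested is meant among the compounds shown, and "the series" means these compounds.

Compound 3 `CC(C)Cc1ccc(C(C)c2nnc3n2N=C(c2ccccc2)CS3)cc1` is one of three close analogues that differ only in the group carried by the aromatic ring on the carbon with a double bond to nitrogen. In a functional assay on Huh-7 cells (Homo sapiens) for inhibition, read by sulforhodamine B assay, with a stated time of 72 h (on this read-out lower numbers stand for stronger inhibition and higher numbers for weaker inhibition), compound 3 gives 6100 nM. Compound 1 `CC(C)Cc1ccc(C(C)c2nnc3n2N=C(c2ccc(Br)cc2)CS3)cc1` gives 4900 nM and compound 2 `Cc1ccc(C2=Nn3c(nnc3C(C)c3ccc(CC(C)C)cc3)SC2)cc1` gives 5000 nM; all three numbers lie within the scatter of one another, so compound 3 stands alongside both rather than apart from them. The move to compound 4 `CC(C)Cc1ccc(C(C)c2nnc3n2N=C(c2ccc(Cl)cc2Cl)CS3)cc1` is 2,4-dichlorophenyl in place of phenyl on a carbon with a double bond to nitrogen. The measured steps that bear on this ring are a 1.2-fold higher number from compound 1 to compound 3 (0.10 log units; within the scatter) and a 1.2-fold higher number from compound 2 to compound 3 (0.09 log units; within the scatter), both within the scatter, so neither a bromo nor a methyl on that ring made a measurable difference. Two chlorines on that ring are not covered by any measured pair, so the expectation is a step in this assay of a 1.2-fold lower number from compound 3 to compound 4 (0.09 log units; within the scatter), nothing beyond the scatter. Compound 4 is therefore estimated at 5000 nM, within 2400 nM to 11000 nM.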

Compound 4, half-maximal inhibitory concentration: 7500 nM
Estimate against measurement, compound 4: 1.5-fold (0.18 log units) below; the range from low to high includes it.
By their numbers in this assay, from the lowest: compounds 1, 2, 3 and 4 (each within the scatter of the next).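

In this assay the 2,4-dichlorophenyl group of compound 4 gives steps of a 1.2-fold higher number from compound 3 to compound 4 (0.09 log units; within the scatter) and a 1.5-fold higher number from compound 2 to compound 4 (0.18 log units; within the scatter) and a 1.5-fold higher number from compound 1 to compound 4 (0.18 log units; within the scatter) and all three stay within the scatter. This extends the earlier picture from single groups on the aromatic ring to a ring carrying two chlorines: on this carbon with a double bond to nitrogen, phenyl, 4-bromophenyl, 4-methylphenyl and 2,4-dichlorophenyl cannot be told apart in this read-out. No measurement is available that would explain why the numbers stay together. From the compounds shown here alone, it remains open whether an amine or a carboxylic acid on this aromatic ring, or a longer chain in place of the ring, would give a step beyond the scatter. The same question stands for changes elsewhere on the shared core, since all four compounds keep it unchanged.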